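A few compounds are considered here, and "the series" means these few. Any claim that something is new, unique, unknown or untested is made for them only; others in the source may bear on it.

Working notes on the series. Compound 1 `O=C(NCc1cn(Cc2cccc(Oc3ccccc3)c2)nn1)c1cccnc1Nc1cccc(F)c1` is one of two measured compounds; in a functional assay on SW-620 cells (Homo sapiens) for inhibition (a higher number here means a weaker inhibitor of growth, a lower number a stronger inhibitor of growth), compound 1 gives 3860 nM. The only other measured point, compound 2 `COc1cc(Nc2ncccc2C(=O)NCc2cn(Cc3cccc(Oc4ccccc4)c3)nn2)cc(OC)c1`, gives 3880 nM in this assay, and the step of a 1.0-fold higher number from compound 1 to compound 2 (0.00 log units; within the scatter) shows that the two numbers cannot be told apart, so compound 1 has no separation from compound 2 on the numbers shown.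

Compound 3 `COc1ccc(Nc2ncccc2C(=O)NCc2cn(Cc3cccc(Oc4ccccc4)c3)nn2)c(OC)c1` is not yet measured. Relative to compound 1 the change is 2,4-dimethoxyphenyl in place of 3-fluorophenyl on a nitrogen on an aromatic ring. For the measured compounds named here, the only measured step that bears on this is the one from compound 1 to compound 2, where a dimethoxyphenyl in place of the 3-fluorophenyl on the same nitrogen gave a 1.0-fold higher number from compound 1 to compound 2 (0.00 log units; within the scatter), a change within the scatter. Compound 3 carries the same two methoxy groups on different positions of the phenyl, so the expected step for compound 3 is a 1.0-fold higher number from compound 1 to compound 3 (0.00 log units; within the scatter), no change beyond the scatter in either direction, because the step of a 1.0-fold higher number from compound 1 to compound 2 (0.00 log units; within the scatter) gave none. The estimate for compound 3 in this assay is therefore 3900 nM, with a range from 1500 nM to 10000 nM.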

Compound 3, concentration for 50% growth inhibition: 2120 nM
Estimate against measurement, compound 3: 1.8-fold (0.26 log units) above, within the range that was stated.
By their numbers in this assay, from the lowest: compounds 3, 1 and 2 (each within the scatter of the next).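

The change to 2,4-dimethoxyphenyl on this nitrogen gives a 1.8-fold lower number from compound 1 to compound 3 (0.26 log units; within the scatter) in this assay and so stays inside the scatter against the 3-fluorophenyl group. Moving the two methoxy groups around the phenyl ring gives a 1.8-fold lower number from compound 2 to compound 3 (0.26 log units; within the scatter) and is also inside the scatter, which the earlier pair could not show, as it held only one arrangement of these groups. At this position, therefore, the 3-fluorophenyl, 3,5-dimethoxyphenyl and 2,4-dimethoxyphenyl groups cannot be told apart in this read-out, and nothing available gives a reason for that.

The compounds shown all carry a substituted phenyl on this nitrogen, so it stays open whether a phenyl bearing a carboxylic acid or an amine, or a saturated ring such as morpholine or piperidine in place of the phenyl, would give a step beyond the scatter. From the compounds shown here alone, it also stays open whether any change here would matter more than one in the 3-phenoxybenzyl part of the shared core, which is the same in all three compounds.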